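A Double Bond Turned: From Compound 3 to Compound 4

A few compounds are considered here, and "the series" means these few. Any claim that something is new, unique, unknown or untested is made for them only; others in the source may bear on it.

Compound 1, `CC/C=C/C=C/CCc1cc(O)c([C@@H]2O[C@H](CO)[C@@H](O)[C@H](O)[C@H]2O)c(O)c1C(=O)OC`, gives 19000 nM in a functional assay on RAW264.7 cells (Mus musculus) for inhibition, read by Griess assay, with stated times of 2 h and 12 h; a higher number here means a weaker inhibitor, a lower number a stronger inhibitor.
Compound 2, `C/C=C/C=C/CCc1cc(O)c([C@@H]2O[C@H](CO)[C@@H](O)[C@H](O)[C@H]2O)c(O)c1C(=O)OC`, is reported in this assay only as a limit, > 40000 nM.
Compound 3, `CCC/C=C/C=C/CCc1cc(O)c([C@@H]2O[C@H](CO)[C@@H](O)[C@H](O)[C@H]2O)c(O)c1`, is likewise reported only as a limit, > 40000 nM.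

Compound 3 therefore stands not at a number but at the limit of this assay, the limit described by the limit of > 40000 nM in this assay, at which 2 of the 3 values shown sit. Compound 4, `CCC/C=C\C=C\CCc1cc(O)c([C@@H]2O[C@H](CO)[C@@H](O)[C@H](O)[C@H]2O)c(O)c1`, differs from it in this way: the two compounds have the same atoms and bonds and differ only in configuration as drawn: 1 of 7 stereo elements differ; a double bond is drawn E in compound 3 and Z in compound 4. The one step measured among these compounds, an at least 2.1-fold higher number from compound 1 to compound 2 (0.32 log units; beyond the scatter), concerns a change in the chain itself and not its geometry, so it does not bear on the step from compound 3 to compound 4. Among the measured compounds shown here, no measured step speaks to a turn from E to Z. Without any such step, compound 4 is expected to sit where compound 3 sits, and the estimated step that the limit leaves unreadable from compound 3 to compound 4 is therefore none beyond the scatter. In this assay compound 4 is accordingly expected to give about 50000 nM, most likely again only a limit, with an estimated range from 20000 nM to 150000 nM.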

Compound 4, half-maximal inhibitory concentration: 30000 nM
Beside the measured number, compound 4's estimate is 1.7-fold (0.22 log units) above it, within the range that was stated.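

Among the compounds shown, this pair is the only one read for a change of geometry alone, and in this assay the turn of this one double bond gives an at least 1.3-fold lower number from compound 3 to compound 4 (0.12 log units; that floor lies within the scatter). On these data alone, for compound 3 the reading > 40000 nM is a limit, so the step taken from it is a floor and its true size stays open. Compound 4 gives 30000 nM as a measured number. Among the compounds shown here, since no atom enters or leaves, the only thing that separates compound 4 from compound 3 is the geometry of a single double bond: the fact that compounds 3 and 4 differ only in the configuration as drawn.

The compounds shown leave open whether turning the other double bond of the chain would read the same way, and whether the same turn would count in a compound carrying the methyl ester of compound 1. They also leave open how a carboxylic acid in place of that ester, or a longer chain bearing the Z double bond, would stand in this assay.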